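The compounds below may be only part of what the source reports. "The series", "measured", "known", "first", "only" and "open" are said of these compounds alone.

Values in a functional assay on HL-60 cells (Homo sapiens) for cytotoxicity, read by WST assay, with a stated time of 48 h; a higher number here means that more compound is needed for the effect, a lower number that less compound is needed:
Compound 1 `O=C1OC[C@H](Cc2ccccc2)[C@H]1Cc1ccccc1`: 77000 nM
Compound 2 `O=C1OC[C@H](Cc2ccccc2)[C@H]1Cc1cccc(F)c1`: 75000 nM

Among the measured compounds shown here, compound 2 stands level with compound 1, the only other measured compound, and the two lie within the scatter of each other. Next is compound 3 `O=C1OC[C@H](Cc2ccccc2)[C@H]1Cc1cccc(Cl)c1`, which differs from compound 2 as follows: chloro in place of fluoro on an aromatic carbon. This places chloro in place of fluoro on an aromatic carbon, meta to a large group. For the measured compounds named here, only one measured step bears on this change, a fluoro in place of hydrogen on an aromatic carbon: a 1.0-fold lower number from compound 1 to compound 2 (0.01 log units; within the scatter). That single step gives thin support, but no step beyond the scatter is expected in this assay. The expected change is a 1.2-fold lower number from compound 2 to compound 3 (0.06 log units; within the scatter). Compound 3 is estimated at 65000 nM, with an expected range of 35000 nM to 110000 nM.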

Compound 3, half-maximal effective concentration: 36000 nM
For compound 3 the middle estimate is 1.8-fold (0.26 log units) above the measured one, within the range that was stated.
By their numbers in this assay, from the lowest: compound 3; then compounds 2 and 1 (each within the scatter of the next).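

Chloro in place of hydrogen at this position, meta to a large group, gives a 2.1-fold lower number from compound 1 to compound 3 (0.33 log units; beyond the scatter) in this assay and chloro in place of fluoro gives a 2.1-fold lower number from compound 2 to compound 3 (0.32 log units; beyond the scatter) as the first steps in the series beyond the scatter. The position does respond to its substituent, if modestly, and the two halogens part here, while fluoro in place of hydrogen stayed within the scatter. No measurement at hand accounts for the difference between chloro and fluoro.

From the compounds shown here alone, whether bromo, methyl or methoxy at this position would lower the number further stays open. So does whether chloro has the same effect elsewhere on this ring or on the other aromatic ring.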